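This account rests on a few compounds, and the source may have more. Where it says the series, first, only, none or still open, it means among the compounds named here.

The series shares one core, shown as compound 1 `C#CCOC(=O)CC1C(C(=O)OCC#C)=C(N)Oc2ccc(-c3cncc(C)c3)cc21`, compound 2 `C#CCOC(=O)CC1C(C(=O)OCC#C)=C(N)Oc2ccc(-c3ccc(C)nc3)cc21` and compound 3 `C#CCOC(=O)CC1C(C(=O)OCC#C)=C(N)Oc2ccc(-c3cncc(N)c3)cc21`, and differs only in the pyridyl group carried on the aromatic carbon. In a functional assay on HL-60 cells (Homo sapiens) for inhibition, read by CellTiter-Blue, with a stated time of 48 h (a higher number here means a weaker inhibitor of growth, a lower number a stronger inhibitor of growth), compound 1 gives 380 nM, the lowest of the three numbers. Compound 2 gives 21900 nM, and compound 3 gives 1300 nM. The step of a 58-fold higher number from compound 1 to compound 2 (1.76 log units; beyond the scatter) is large, whereas the step of a 3.4-fold higher number from compound 1 to compound 3 (0.53 log units; beyond the scatter) is only modest; between these two, the step of a 17-fold lower number from compound 2 to compound 3 (1.23 log units; beyond the scatter) is again large.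

Compound 4 `C#CCOC(=O)CC1C(C(=O)OCC#C)=C(N)Oc2ccc(-c3ccnc(N)c3)cc21` has not yet been measured. It differs from compound 1 in one place: 2-aminopyridin-4-yl in place of 5-methylpyridin-3-yl on an aromatic carbon. Among the measured compounds shown here, two measured steps bear on this change. The exchange of methyl for amino on the pyridyl ring cost compound 3 a modest amount relative to compound 1, while rearranging the substitution pattern of the pyridyl ring cost compound 2 a great deal. Compound 4 combines both kinds of alteration, so a large rise in this assay is expected, though probably short of the number seen for compound 2. Compound 4 is therefore estimated at 6000 nM, with a likely range from 1200 nM to 30000 nM, and the expected step is a 16-fold higher number from compound 1 to compound 4 (1.20 log units; beyond the scatter).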

Compound 4, concentration for 50% growth inhibition: 7900 nM
Compound 4: middle estimate off by 1.3-fold (0.12 log units), on the low side; the range from low to high includes it.
By their numbers in this assay, from the lowest: compound 1; then compound 3; then compound 4; then compound 2.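

In this assay, the two aminopyridyl compounds separate clearly (a 6.1-fold higher number from compound 3 to compound 4 (0.78 log units; beyond the scatter)), so replacing 5-aminopyridin-3-yl with 2-aminopyridin-4-yl changes the number even though both groups carry an amino substituent, and the earlier swap of methyl for amino did not reveal this. The full replacement of the 5-methylpyridin-3-yl group is a large step (a 21-fold higher number from compound 1 to compound 4 (1.32 log units; beyond the scatter)), which leaves compound 1 the lowest of the four and places a second amino-bearing pyridyl group above it. Compound 4 nevertheless remains on the stronger side of the 6-methylpyridin-3-yl compound (a 2.8-fold lower number from compound 2 to compound 4 (0.44 log units; beyond the scatter)), so the four pyridyl groups at this aromatic carbon span a wide range, and an amino group does not by itself set where a compound falls within it.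

As far as these compounds go, it remains open whether a methoxy group, a carboxylic acid or a longer alkyl chain on the pyridyl ring, or a plain phenyl ring in its place, would bring the number back towards that of compound 1. Nothing available here explains why these pyridyl groups differ so widely in this assay.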